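The source may report more compounds than this note shows. Statements on the series, on what has been measured and on what is new or still open speak of the compounds shown alone.

Measured so far:
compound 1, `COc1ccc(F)cc1CNCCCNc1ccnc2cc(C3CCCCC3)ccc12` — 23 10^-6 cm/s
compound 2, `COc1ccc(F)cc1CNCCCNc1ccnc2cc(Oc3ccc(F)cc3)ccc12` — 317 10^-6 cm/s
compound 3, `COc1ccc(F)cc1CNCCCNc1ccnc2cc(Cc3ccccc3)ccc12` — 23 10^-6 cm/s

These three compounds share one core and differ only in the group attached to one aromatic carbon of it. In an ADME assay for permeability, using PAMPA, with a stated time of 30 min, at pH 7.4 (on this read-out higher numbers stand for higher permeability and lower numbers for lower permeability), compound 3 gives 23 10^-6 cm/s, which places it level with compound 1 and, together with compound 1, at the bottom of the three numbers. The step of no change at the digits printed from compound 1 to compound 3 (within the scatter) is within the scatter, whereas a 14-fold lower number from compound 2 to compound 3 (1.14 log units; beyond the scatter) and a 14-fold higher number from compound 1 to compound 2 (1.14 log units; beyond the scatter) are both large.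

Compound 4, `COc1ccc(-c2ccc3c(NCCCNCc4cc(F)ccc4OC)ccnc3c2)cc1`, is the next compound to be measured. The change from compound 3 is 4-methoxyphenyl in place of benzyl on an aromatic carbon.

Among the compounds with values here, no measured step swaps the benzyl for a directly attached aromatic ring, so the bearing of the known steps is indirect. Within the data shown here, the two groups that gave low numbers, cyclohexyl and benzyl, are joined to the core through a saturated carbon; the one high number came with the 4-fluorophenoxy group. This leaves the direction open, and a wide range is warranted. The expected step for compound 4 is a 2.2-fold higher number from compound 3 to compound 4 (0.34 log units; beyond the scatter), a modest rise that stays short of compound 2. Compound 4 is estimated at 50 10^-6 cm/s, between 12 10^-6 cm/s and 200 10^-6 cm/s.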

Compound 4, apparent permeability: 237 10^-6 cm/s
Estimate against measurement, compound 4: 4.7-fold (0.68 log units) below; measured number above the stated range.
By their numbers in this assay, from the lowest: compounds 1 and 3 (each within the scatter of the next); then compounds 4 and 2 (each within the scatter of the next).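

In this assay, the 4-methoxyphenyl group changes the picture at this aromatic carbon: a 10-fold higher number from compound 3 to compound 4 (1.01 log units; beyond the scatter), and likewise a 10-fold higher number from compound 1 to compound 4 (1.01 log units; beyond the scatter), while a 1.3-fold lower number from compound 2 to compound 4 (0.13 log units; within the scatter). Within the data shown here, the high number is therefore not unique to the 4-fluorophenoxy group, and across these four compounds the two groups joined through a saturated carbon, cyclohexyl and benzyl, give the low numbers, with no compound going against that split. No measurement shown here explains the split.

Going by these compounds, it remains open whether the methoxy on the new ring plays any part, which a plain phenyl group at this position could test. On these data alone, how an amine or a carboxylic acid at the same carbon would compare also remains unknown.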